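Two methoxy groups in place of two chlorines

A few compounds are considered here, and "the series" means these few. Any claim that something is new, unique, unknown or untested is made for them only; others in the source may bear on it.

compound 1 `COc1cc(-c2cc(/C=C/C(=O)c3ccc(Cl)c(Cl)c3)[nH]n2)cc(OC)c1OC` — > 100000 nM
compound 2 `COc1ccc(-c2cc(/C=C/C(=O)c3ccc(N)cc3)[nH]n2)cc1OC` — > 100000 nM
compound 3 `COc1ccc(-c2cc(/C=C/C(=O)c3ccc(N)cc3)[nH]n2)cc1` — 39800 nM

All three were tested in a functional assay on PC-3 cells (Homo sapiens) for inhibition, read by sulforhodamine B assay, with a stated time of 48 h; on this read-out higher numbers stand for lower toxicity in this test and lower numbers for higher toxicity in this test. In this assay compound 1 gives only a limit, > 100000 nM, and no number. Compound 2 also stops at a limit in this assay, > 100000 nM. Compound 3 gives a number in this assay, 39800 nM. Within the data shown here, the single measured step, an at least 2.5-fold lower number from compound 2 to compound 3 (0.40 log units; beyond the scatter), goes with hydrogen in place of methoxy on an aromatic carbon: removing a methoxy moved the read-out toward the more toxic side. Compound 1 thus sits at the upper edge of what this assay reports, as the limit of > 100000 nM in this assay, at which 2 of the 3 values shown sit, shows.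

Compound 4 `COc1ccc(C(=O)/C=C/c2cc(-c3cc(OC)c(OC)c(OC)c3)n[nH]2)cc1OC` is compound 1 with 3,4-dimethoxyphenyl in place of 3,4-dichlorophenyl on a carbonyl carbon. Among the measured compounds shown here, no measured step touches this part of the shared core. For the measured compounds named here, the one known step, an at least 2.5-fold lower number from compound 2 to compound 3 (0.40 log units; beyond the scatter), points the other way from adding methoxy groups, so nothing here suggests a lower number for compound 4. Compound 4 is therefore expected to remain at or near the limit, with an estimate of 100000 nM in this assay, between 30000 nM and 300000 nM. This expectation amounts to a number no higher from compound 1 to compound 4 (the limit leaves the size open), expected to be no change beyond the scatter.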

Compound 4, concentration lethal to 50% of the cells: 5760 nM
Compound 4: the middle estimate sits 17-fold (1.24 log units) above what was measured; measured number below the stated range.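

Among these compounds, the aromatic group on the carbonyl carbon, which no earlier step touched, turns out to matter in this assay: swapping 3,4-dichlorophenyl for 3,4-dimethoxyphenyl gives an at least 17-fold lower number from compound 1 to compound 4 (1.23 log units; beyond the scatter), moving the read-out well toward the more toxic side. Methoxy groups therefore do not go with a higher number wherever they stand, since here their arrival goes with a lower number, while the earlier step, an at least 2.5-fold lower number from compound 2 to compound 3 (0.40 log units; beyond the scatter), came from removing one at a different place. The size of the new step is only a minimum because compound 1 stops at a limit rather than a number: the limit of > 100000 nM in this assay, at which 2 of the 4 values shown sit.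

On these data alone, whether the loss of the chlorines or the arrival of the methoxy groups carries this step remains open. So does how a plain phenyl group, or a phenyl carrying a single fluorine, would read on the same carbonyl carbon.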